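The source may report more compounds than this note shows. Statements on the series, on what has been measured and on what is new or still open speak of the compounds shown alone.

Measured so far in a functional assay on A549 cells (Homo sapiens) for cytotoxicity, read by MTT assay, with a stated time of 72 h; a higher number here means a weaker inhibitor, a lower number a stronger inhibitor:
compound 1 `COc1cc2c(Oc3ccc(NC(=O)c4cc(-c5ccccc5)ccn4)cc3F)ccnc2cc1OCCCN1CCN(C)CC1` gives 340 nM;
compound 2 `COc1cc2c(Oc3ccc(NC(=O)c4cc(-c5ccc(F)cc5)ccn4)cc3F)ccnc2cc1OCCCN1CCCCC1` gives 10100 nM;
compound 3 `COc1cc2c(Oc3ccc(NC(=O)c4cc(-c5ccccc5F)ccn4)cc3F)ccnc2cc1OCCCN1CCCCC1` is recorded as "not determined" (no result reported) in this assay, that is, without a reported result.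

Among the compounds with values here, compound 3 therefore stands without a number in this assay; only compounds 1 and 2 carry values, and those two differ in more than one place, so no single step between them is set out. Compound 4 `COc1cc2c(Oc3ccc(NC(=O)c4cc(-c5ccc(C(F)(F)F)cc5)ccn4)cc3F)ccnc2cc1OCCCN1CCCCC1` differs from compound 3 by one change: 4-(trifluoromethyl)phenyl in place of 2-fluorophenyl on an aromatic carbon. Within the data shown here, with no measured step for this kind of change and no value for compound 3, the direction and size of the step cannot be judged from the data; a step beyond the scatter in either direction is possible. Compound 4 is expected to give about 5000 nM in this assay, within 800 nM to 30000 nM.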

Compound 4, half-maximal inhibitory concentration: 1640 nM
Compound 4: middle estimate off by 3.0-fold (0.48 log units), on the high side; the range from low to high includes it.
By their numbers in this assay, from the lowest: compound 1; then compound 4; then compound 2.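

Trifluoromethyl in place of fluoro on the phenyl group gives a 6.2-fold lower number from compound 2 to compound 4 (0.79 log units; beyond the scatter) in this assay, the first single change here that can be read, and it shows that the number at this site moves with the group the phenyl carries. Compound 3 has no reported result, so the step from it to compound 4 cannot be read. Nothing measured here accounts for the step.

The compounds shown leave open how a nitrile, a methoxy group or an amine would read in place of trifluoromethyl. They also leave open whether the same change would give a similar step on the side chain of compound 1.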